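From a 4-methylphenyl group to methyl on compound 3

A few compounds are considered here, and "the series" means these few. Any claim that something is new, unique, unknown or untested is made for them only; others in the source may bear on it.

In an ADME assay on cells (Hepatocyte, Mus musculus) for metabolic stability, with a stated time of 30 min (a lower number here means that less of the compound is left, a higher number that more of the compound is left), compound 1 (`CS(=O)(=O)NC1CCC(CN2CCN(c3cc(=O)c4cc(C(F)(F)F)cc([N+](=O)[O-])c4s3)CC2)CC1`) shows 111% and compound 2 (`O=c1cc(N2CCN(CC3CCC(NS(=O)(=O)c4ccccc4)CC3)CC2)sc2c([N+](=O)[O-])cc(C(F)(F)F)cc12`) shows 95.3% while compound 3 (`Cc1ccc(C(=O)OC2CCC(CN3CCN(c4cc(=O)c5cc(C(F)(F)F)cc([N+](=O)[O-])c5s4)CC3)CC2)cc1`) stands lowest with 18% left. Compound 4 (`CC(=O)OC1CCC(CN2CCN(c3cc(=O)c4cc(C(F)(F)F)cc([N+](=O)[O-])c4s3)CC2)CC1`) carries methyl in place of 4-methylphenyl on a carbonyl carbon and so has acetoxy where compound 3 has ((4-methylphenyl)carbonyl)oxy. Two large steps came with that group: a number 93 percentage points lower from compound 1 to compound 3 (beyond the scatter) and a number 77.3 percentage points lower from compound 2 to compound 3 (beyond the scatter) on arrival. Compound 4 keeps the carbonyl and its oxygen, so it is expected to stay low. The closest swap of phenyl and methyl, on a sulfonyl sulfur, gave only a number 15.7 percentage points lower from compound 1 to compound 2 (beyond the scatter) and was modest. The expected outcome is no step beyond the scatter, estimated as a number 2 percentage points higher from compound 3 to compound 4 (within the scatter) only. For compound 4 the estimate is 20% within an expected range of 4% to 48% remaining.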

Compound 4, percent of the compound remaining: 0%
Compound 4: the middle estimate sits 20 percentage points above what was measured; measured number outside the range, below it.
By their numbers in this assay, from the lowest: compound 4; then compound 3; then compound 2; then compound 1.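

Replacing 4-methylphenyl with methyl on the carbonyl carbon does not lift the number in this assay (a number 18 percentage points lower from compound 3 to compound 4 (beyond the scatter)), so the low number of compound 3 does not depend on the 4-methylphenyl group. Acetoxy stands far under both sulfonyl-bearing groups (a number 95.3 percentage points lower from compound 2 to compound 4 (beyond the scatter); a number 111 percentage points lower from compound 1 to compound 4 (beyond the scatter)), and both compounds with a carbonyloxy group lie low. Nothing measured here explains why.

Still open, going by these compounds, is whether an amide on that saturated ring carbon would stay as high as compound 1 and compound 2. A plain hydroxyl or amine there is equally unresolved.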